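The source may report more compounds than this note shows. Statements on the series, on what has been measured and on what is new or still open speak of the compounds shown alone.

Measured compounds:
compound 1, `COc1ccc2c(c1)C(CCCN1CCN(c3ccccc3OC)CC1)=CCC2`, 24.5 nM
compound 2, `COc1ccc2c(c1)C(NCCN1CCN(c3ccccc3OC)CC1)CCC2`, 1960 nM

Both were tested in an assay on isolated protein for binding affinity to Adrenergic receptor alpha-1 (Rattus norvegicus), read by radioligand binding; a higher number here means a weaker inhibitor, a lower number a stronger inhibitor. Of the two numbers, compound 1 holds the lower one, so it is the stronger binder of this pair; compound 2 sits far above it, well beyond the usual scatter. Among the compounds with values here, no single-point step joins these two compounds, so nothing more is read from them.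

Compound 3 is `COc1ccc2c(c1)C(CCCN1CCN(c3cccc(C(F)(F)F)c3)CC1)=CCC2`, which is not yet measured. It keeps the whole core of compound 1 and differs in one place only: 3-(trifluoromethyl)phenyl in place of 2-methoxyphenyl on an amine nitrogen in a ring. The new arene carries no hydrogen-bond acceptor, whereas the departing one carried one.

There is no measured step of this kind in the set, so the expectation rests on the exchange alone. The change is expected to weaken binding somewhat, giving a step of a 4.1-fold higher number from compound 1 to compound 3 (0.61 log units; beyond the scatter), a moderate rise rather than the large one seen for compound 2. Compound 3 is therefore expected to give about 100 nM in this assay, with a plausible range from 25 nM to 400 nM.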

Compound 3, half-maximal inhibitory concentration: 3070 nM
Compound 3: the middle estimate sits 31-fold (1.49 log units) below what was measured; measured number above the stated range.
By their numbers in this assay, from the lowest: compound 1; then compounds 2 and 3 (each within the scatter of the next).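

On the amine nitrogen in a ring, the choice of aryl group matters greatly in this assay: 3-(trifluoromethyl)phenyl in place of 2-methoxyphenyl gives a 130-fold higher number from compound 1 to compound 3 (2.10 log units; beyond the scatter), although the rest of compound 1 stays the same. Within the data shown here, this is the first single-place change in the set, and it shows that, at this position, one substituted phenyl group cannot simply stand in for another without a large loss of binding. Nothing at hand explains why the number rises so far.

Because the exchange changes both the substituent and where it sits on the phenyl ring, the step cannot show which of the two drives the loss. On these data alone, it also remains open how a plain phenyl group or a 2-ethoxyphenyl group on the same nitrogen would compare with compound 1.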